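The source may hold more compounds than are shown below. What is called first, only, known or untested is meant among the compounds shown, and "the series" means these compounds.

Measured compounds:
Compound 1 `CC1CCC(Nc2nc(C(F)(F)F)ccc2CNC(=O)C(C)c2ccc(NS(C)(=O)=O)c(F)c2)CC1`: 27.2 nM
Compound 2 `CC(C(=O)NCc1ccc(C(F)(F)F)nc1N1CCC(Cc2cc(F)cc(F)c2)CC1)c1ccc(NS(C)(=O)=O)c(F)c1`: 0.4 nM

In a functional assay on CHO-K1 cells for antagonist activity at transient receptor potential cation channel subfamily V member 1 (Homo sapiens), read by FLIPR (a higher number here means a weaker inhibitor, a lower number a stronger inhibitor), compound 2 gives 0.4 nM, the lowest of the two numbers seen here. For the measured compounds named here, the only other measured compound, compound 1, gives 27.2 nM in this assay, a much higher number, and the gap between the two lies beyond the usual scatter. Going by the values given here, the two structures differ in more than one place, so their values show only that compound 2 is the stronger inhibitor of the pair and nothing about any single change.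

Compound 3 `CC(C(=O)NCc1ccc(C(F)(F)F)nc1N1CCC(C(F)(F)F)CC1)c1ccc(NS(C)(=O)=O)c(F)c1` has not yet been measured in this assay. It differs from compound 2 in one place: trifluoromethyl in place of 3,5-difluorobenzyl on a saturated ring carbon. Among the compounds with values here, no measured pair shows this exact change, so its effect has to be estimated from what the two measured compounds offer. Because compound 2 gives 0.4 nM while compound 1 gives 27.2 nM, a step toward a higher number is expected for compound 3, larger than the scatter, though not as far as compound 1. The expected step is a 10-fold higher number from compound 2 to compound 3 (1.00 log units; beyond the scatter). For compound 3 the estimate in this assay is 4 nM, expected between 0.8 nM and 25 nM.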

Compound 3, inhibition constant: 0.6 nM
Beside the measured number, compound 3's estimate is 6.7-fold (0.82 log units) above it; the whole stated range lies above it.
By their numbers in this assay, from the lowest: compounds 2 and 3 (each within the scatter of the next); then compound 1.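

In this assay there is a 1.5-fold higher number from compound 2 to compound 3 (0.18 log units; within the scatter) when trifluoromethyl takes the place of 3,5-difluorobenzyl on the saturated ring carbon, so at this position a group without a ring and with fewer heavy atoms serves as well as the larger benzyl group, at least in these two compounds. For the compounds shown here, the change also gives the first comparison with compound 1 that differs in one place: there is a 45-fold lower number from compound 1 to compound 3 (1.66 log units; beyond the scatter) when 4-(trifluoromethyl)piperidin-1-yl takes the place of (4-methylcyclohexyl)amino on an aromatic carbon, which ties a large step to that single exchange on the shared core. Nothing in the data accounts for either step.

The compounds shown leave open whether this saturated ring carbon accepts groups of another kind, such as an amine or a carboxylic acid, with a number as low as those of compound 2 and compound 3. They also leave open which part of the larger exchange carries the step, a question that a 4-methylpiperidin-1-yl group on the same aromatic carbon would help to divide.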